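The source may report more compounds than this note shows. Statements on the series, on what has been measured and on what is new or still open speak of the compounds shown alone.

Of the compounds shown here, three sharing one core have been tested in a functional assay on T47D cells (Homo sapiens) for cytotoxicity, read by MTT assay, with a stated time of 48 h; a lower number here means a stronger inhibitor, a higher number a weaker inhibitor: compound 1 `S=C(N/N=C\c1ccnc2ccccc12)Nc1cccnc1` gives 1100 nM, compound 2 `Fc1ccc(NC(=S)N/N=C\c2ccnc3ccccc23)cc1` gives 1070 nM, and compound 3 `S=C(N/N=C\c1ccnc2ccccc12)Nc1ccc(Cl)cc1` gives 1270 nM. Compound 3 stands level with the other two, so these numbers support no ranking among the three.

Compound 4 `C=CCNC(=S)N/N=C\c1ccnc2ccccc12` keeps the shared core and changes one group, with allyl in place of 4-chlorophenyl on an amide-type nitrogen.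

The measured steps that bear on this change are the swaps on that same nitrogen, a 1.0-fold lower number from compound 1 to compound 2 (0.01 log units; within the scatter) and a 1.2-fold higher number from compound 1 to compound 3 (0.06 log units; within the scatter). The exchange of chloro for fluoro, a 1.2-fold higher number from compound 2 to compound 3 (0.07 log units; within the scatter), is also small. Among the compounds with values here, each of these swaps puts one ring-bearing group in place of another, and no tested compound carries an open chain on that nitrogen, so the new change goes beyond what has been measured.

Taking compound 3 at 1270 nM as the starting point, only a slight lean towards a higher number is expected, and it may not exceed the usual scatter. The estimated step is a 1.6-fold higher number from compound 3 to compound 4 (0.20 log units; within the scatter). For compound 4 the expected value is 2000 nM, with an estimated range from 700 nM to 6000 nM.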

Compound 4, half-maximal inhibitory concentration: 1230 nM
Compound 4: middle estimate off by 1.6-fold (0.21 log units), on the high side; measured number inside the range.
By their numbers in this assay, from the lowest: compounds 2, 1, 4 and 3 (each within the scatter of the next).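

In this assay, the step from a ring-bearing group to an open chain on the amide-type nitrogen is a 1.0-fold lower number from compound 3 to compound 4 (0.01 log units; within the scatter), and the same swap measured against the other two compounds is a 1.1-fold higher number from compound 2 to compound 4 (0.06 log units; within the scatter) and a 1.1-fold higher number from compound 1 to compound 4 (0.05 log units; within the scatter). Within the data shown here, until now, only one ring-bearing group had been exchanged for another at this position, whereas allyl has no ring and is smaller than 4-chlorophenyl, yet all four compounds remain within the scatter of one another, and none goes against this. So an aromatic ring on this nitrogen is not needed for a number of this size in this assay, and no measurement shown here explains why the change makes so little difference.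

As far as these compounds go, it remains open whether a longer chain, such as hexyl, or a chain ending in an amine or a carboxylic acid would also stay within the scatter or would finally shift the number. Every compound shown keeps the shared core, so what a change to the core would do also remains unknown.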